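The source may report more compounds than this note shows. Statements on the series, on what has been measured and on what is new or still open speak of the compounds shown alone.

Compound 3 `CCc1nc2c(-c3ccc(OC)nc3C)ccnc2n1C(C)C1CC1` gives 2 nM in an assay for binding affinity to Corticotropin releasing factor receptor (Rattus norvegicus) (on this read-out higher numbers stand for weaker inhibition and lower numbers for stronger inhibition), the highest number among the three measured compounds. Compound 2 `CCc1nc2c(-c3ccc(OC)nc3C)ccnc2n1C(CC)C1CC1` gives 0.7 nM in this assay, and compound 1 `CCc1nc2c(-c3ccc(OC)nc3C(F)(F)F)ccnc2n1C(C)CC` gives 0.7 nM. Among the compounds with values here, the one single-point step within the set, a 2.9-fold higher number from compound 2 to compound 3 (0.46 log units; beyond the scatter), concerns the substituent on the chain carbon and is modest.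

Compound 4 `CCc1nc2c(-c3ccc(OC)nc3C)ccnc2n1C(C)CC` differs from compound 3 by ethyl in place of cyclopropyl on a saturated chain carbon bound to an aromatic nitrogen and a saturated chain carbon. Within the data shown here, no measured step covers this exchange directly. Compound 1 carries the same sec-butyl group as compound 4 but a different group on the pyridine ring, so its values against compound 3 show a difference in two places and cannot be attributed to either. Among the measured compounds shown here, since the only measured step on this chain, from compound 2 to compound 3, was modest, a step of similar or smaller size is expected here, with the direction uncertain and leaning toward a lower number given compound 1 at 0.7 nM. For compound 4 the estimated step is a 2.0-fold lower number from compound 3 to compound 4 (0.30 log units; within the scatter), giving an expected value of 1 nM, within a range of 0.4 nM to 3 nM.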

Compound 4, inhibition constant: 9.2 nM
Compound 4: the middle estimate sits 9.2-fold (0.96 log units) below what was measured, outside the stated range (above it).
By their numbers in this assay, from the lowest: compounds 1 and 2 (each within the scatter of the next); then compound 3; then compound 4.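

In this assay, ethyl in place of cyclopropyl on the saturated chain carbon gives a 4.6-fold higher number from compound 3 to compound 4 (0.66 log units; beyond the scatter) and methyl in place of cyclopropyl at that place gives a 13-fold higher number from compound 2 to compound 4 (1.12 log units; beyond the scatter), so the two cyclopropyl compounds both stand at lower numbers than the sec-butyl compound. Until now the chain had shown only one step, and the cyclopropyl group itself had not been varied. Within the data shown here, the aromatic carbon also comes into view for the first time: with sec-butyl held, methyl in place of trifluoromethyl gives a 13-fold higher number from compound 1 to compound 4 (1.12 log units; beyond the scatter), a large step.

No measurement at hand explains either change. Open, as far as these compounds go, are a cyclobutyl or isopropyl group on the chain carbon, a chlorine on the aromatic carbon, and how trifluoromethyl reads alongside 1-cyclopropylethyl.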